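The compounds below may be only part of what the source reports. "The series", "measured", "known", "first", "only" and "open" are said of these compounds alone.

Values in an ADME assay on HepG2 2.2.15 cells (Homo sapiens) for cytotoxicity; a lower number here means that less compound is tolerated, a higher number that more compound is tolerated:

- compound 1 `O=C(O)CCCC(=O)OCCc1c(-c2ccccc2Cl)c2cc(Cl)ccc2[nH]c1=O`: 110000 nM
- compound 2 `O=C(OCCc1c(-c2ccccc2Cl)c2cc(Cl)ccc2[nH]c1=O)c1cccnc1`: 170000 nM

Compound 2 stands at 170000 nM, within the scatter of compound 1. Compound 3 `O=C(CCOc1ccccc1)OCCc1c(-c2ccccc2Cl)c2cc(Cl)ccc2[nH]c1=O` differs from it as follows: 2-phenoxyethyl in place of pyridin-3-yl on a carbonyl carbon. Within the data shown here, the one measured step, a 1.5-fold higher number from compound 1 to compound 2 (0.19 log units; within the scatter), also exchanged the group on this carbonyl carbon and stayed within the scatter. On that evidence, no step beyond the scatter is expected in this assay. The expected change is a 1.3-fold lower number from compound 2 to compound 3 (0.12 log units; within the scatter). Compound 3 is estimated at 130000 nM, with an expected range from 65000 nM to 260000 nM.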

Compound 3, half-maximal cytotoxic concentration: 46000 nM
The estimate for compound 3 lay 2.8-fold (0.45 log units) above the measured number; measured number below the stated range.
By their numbers in this assay, from the lowest: compound 3; then compounds 1 and 2 (each within the scatter of the next).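

In this assay, the group on this carbonyl carbon can move the number beyond the scatter: 2-phenoxyethyl in place of pyridin-3-yl gives a 3.7-fold lower number from compound 2 to compound 3 (0.57 log units; beyond the scatter), and phenoxy in place of carboxymethyl on the chain gives a 2.4-fold lower number from compound 1 to compound 3 (0.38 log units; beyond the scatter). Less compound is thus tolerated with 2-phenoxyethyl than with either earlier group, although those two groups stayed within the scatter of each other. No measurement at hand accounts for this shift. On these data alone, it remains open whether the ether oxygen matters, and how an amine or a plain alkyl chain on this carbonyl carbon would read in this assay.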